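The source may hold more compounds than are shown below. What is called first, only, known or untested is meant among the compounds shown, and "the series" means these compounds.

Measured so far:
compound 1 `Cc1ccccc1Oc1ccc(N2C[C@@H](C(F)(F)F)C[C@H]2CC(=O)O)cc1` — 73 nM
compound 2 `O=C(O)C[C@@H]1C[C@H](C(F)(F)F)CN1c1ccc(Oc2ccccc2OC(F)(F)F)cc1` — 170 nM

In a functional assay on cells for agonist activity at Free fatty acid receptor 1 (Homo sapiens), read by FLIPR and calcium flux, with a stated time of 100 s (on this read-out lower numbers stand for an effect already at smaller amounts and higher numbers for an effect only at larger amounts of compound), compound 1 gives the lower of the two numbers; compound 2 lies a 2.3-fold higher number from compound 1 to compound 2 (0.37 log units; beyond the scatter) away. Compound 3 `COc1ccc(F)c(Cc2cccc(Oc3ccc(N4C[C@@H](C(F)(F)F)C[C@H]4CC(=O)O)cc3)c2C)c1` differs from compound 1 by 2-fluoro-5-methoxybenzyl in place of hydrogen on an aromatic carbon. Going by the values given here, no measured step touches this kind of change; the only step available alters a group already on the ring, so it offers no direct guide. Compound 3 is therefore expected to land near compound 1, with an estimated step of a 1.5-fold lower number from compound 1 to compound 3 (0.16 log units; within the scatter) that may not exceed the scatter. The estimate for compound 3 is 50 nM, spanning 15 nM to 200 nM.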

Compound 3, half-maximal effective concentration: 500 nM
The estimate for compound 3 lay 10-fold (1.00 log units) below the measured number, outside the stated range (above it).
By their numbers in this assay, from the lowest: compound 1; then compound 2; then compound 3.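

Going by these compounds alone, on the aromatic carbon ortho to a methyl group, 2-fluoro-5-methoxybenzyl in place of hydrogen gives a 6.8-fold higher number from compound 1 to compound 3 (0.84 log units; beyond the scatter) in this assay, the first measured change at this position. The position therefore tolerates this large group with activity retained, but the number rises beyond the scatter. No available evidence bears on this result.

The compounds shown leave open whether a smaller group there, such as a methoxy or an amine, would shift the number as far. They also do not separate the contribution of the ring from those of its fluorine and methoxy substituents, which an unsubstituted benzyl could address.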